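A few compounds are considered here, and "the series" means these few. Any claim that something is new, unique, unknown or untested is made for them only; others in the source may bear on it.

Compound 3 `c1cn2cc(-c3ccsc3)nc(-c3ccc4ncn(C5CCCCC5)c4c3)c2n1` sits second highest of the three compounds measured in a functional assay on SK-MEL-5 cells (Homo sapiens) for inhibition, read by sulforhodamine B assay, with a stated time of 48 h, tested at 10 uM (on this read-out higher numbers stand for more inhibition at the one concentration tested (going by the name of the read-out) and lower numbers for less inhibition), at 25%. Its nearest neighbour is compound 1 `c1ccc(-c2cn3ccnc3c(-c3ccc4ncn(C5CCCCC5)c4c3)n2)cc1`, which in this assay gives 36.5%, while compound 2 `c1ccc2c(-c3cn4ccnc4c(-c4ccc5ncn(C6CCCCC6)c5c4)n3)cccc2c1` gives 4.06% and lies furthest away. The steps that connect them are known: a number 11.5 percentage points lower from compound 1 to compound 3 (beyond the scatter), and a number 32.4 percentage points lower from compound 1 to compound 2 (beyond the scatter), whereas a number 20.9 percentage points higher from compound 2 to compound 3 (beyond the scatter).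

Compound 4 `Clc1ccc(-c2cn3ccnc3c(-c3ccc4ncn(C5CCCCC5)c4c3)n2)cc1` has not yet been measured in this assay. It differs from compound 3 in one place: 4-chlorophenyl in place of thiophen-3-yl on an aromatic carbon. Among the compounds with values here, two measured steps bear on this change. The step from compound 1 to compound 3 shows how a thiophen-3-yl compares with a phenyl on this aromatic carbon, and the step from compound 1 to compound 2 shows what a much larger aromatic group does there. A 4-chlorophenyl is a six-membered carbon ring like the phenyl of compound 1, with a chlorine added, so a modest rise toward the number of compound 1 is expected, tempered by the large drop seen with naphthalen-1-yl. For compound 4 the expected step is a number 5 percentage points higher from compound 3 to compound 4 (within the scatter), and the estimate for compound 4 in this assay is 30%, from 10% to 52%.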

Compound 4, a percentage reported as inhibition, at one concentration (the size of the read-out at that concentration, not a potency): 12.4%
For compound 4 the middle estimate is 17.6 percentage points above the measured one; the range from low to high includes it.
By their numbers in this assay, from the lowest: compounds 2 and 4 (each within the scatter of the next); then compound 3; then compound 1.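

In this assay, a single chloro in place of hydrogen on the phenyl ring is enough to register, with a number 24.1 percentage points lower from compound 1 to compound 4 (beyond the scatter), so this position responds to a small addition to the phenyl and not only to a group as large as naphthalen-1-yl. The 4-chlorophenyl also fails to match thiophen-3-yl, with a number 12.6 percentage points lower from compound 3 to compound 4 (beyond the scatter), yet it cannot be told apart from naphthalen-1-yl, with a number 8.3 percentage points higher from compound 2 to compound 4 (within the scatter). Nothing measured here explains why these steps take the sizes they do.

All the groups shown on this aromatic carbon are aromatic rings, so it remains open how an amine or a short alkyl chain would read there. Going by these compounds, it also remains open whether a fluoro or methoxy group on the phenyl ring would give a step like that of the chloro.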